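Working notes: aryloxy to benzylamino on the shared core

This account rests on a few compounds, and the source may have more. Where it says the series, first, only, none or still open, it means among the compounds named here.

Measured compounds:
compound 1, `Nc1cc(N)c2nc(-c3ccccc3)c(Oc3ccc(Cl)c(Cl)c3)nc2c1`, < 100000 nM
compound 2, `CCOC(=O)[C@H](CCC(=O)O)NC(=O)c1ccc(CNc2nc3cc(N)cc(N)c3nc2-c2ccccc2)cc1`, < 100000 nM
compound 3, `COc1cc(CNc2nc3cc(N)cc(N)c3nc2-c2ccccc2)cc(OC)c1OC`, 37200 nM

Three compounds on the shared core have been run in a functional assay on HCT-116 cells (Homo sapiens) for inhibition, read by sulforhodamine B assay, with a stated time of 48 h; on this read-out lower numbers stand for higher toxicity in this test and higher numbers for lower toxicity in this test. Compound 1 gives < 100000 nM in this assay; that is a limit of the assay, not a number. Compound 2 likewise stands only at a limit, < 100000 nM. Among the measured compounds shown here, compound 3 is the one compound with a measured number, 37200 nM. Compound 1 therefore cannot be ordered against the other two; all that can be said is that it sits at the limit of < 100000 nM in this assay, at which 2 of the 3 values shown sit.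

Compound 4, `Nc1cc(N)c2nc(-c3ccccc3)c(NCc3ccc(F)cc3)nc2c1`, is not yet measured. It differs from compound 1 in one place: (4-fluorobenzyl)amino in place of 3,4-dichlorophenoxy on an aromatic carbon. For the measured compounds named here, no step between measured compounds that differ in one place exists in this set, so the size of the step from compound 1 to compound 4 cannot be read from measured data. Going by the values given here, the expectation leans on compound 3, the only compound with a number, 37200 nM. Compound 1, by contrast, stands only at a limit of the assay. A number within the measurable range is expected for compound 4, estimated at 30000 nM with a range from 9000 nM to 95000 nM. The expected step is a step that the limit leaves unreadable from compound 1 to compound 4, though a limit remains a real possibility.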

Compound 4, concentration lethal to 50% of the cells: < 100000 nM
Compound 4 ended at the assay's limit; the forecaster's own chance of this, stated with the estimate: 35%; the middle value lies beyond the limit too.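

Compound 4 gives < 100000 nM, which is a limit of the assay and not a number. No step from compound 1 to compound 4 can be read, as compound 1 also stands only at a limit: the limit of < 100000 nM in this assay, at which 3 of the 4 values shown sit.

The compounds shown leave open whether (4-fluorobenzyl)amino in place of 3,4-dichlorophenoxy on the shared core changes the read-out at all.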